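Removing the hydroxymethyl group: compound 1 to compound 4

The compounds below may be only part of what the source reports. "The series", "measured", "known", "first", "only" and "open" are said of these compounds alone.

Compound 1 `OC[C@@H](O[C@H]1CCCN(Cc2ncc[nH]2)[C@H]1c1ccccc1)c1cc(Cl)cc(Cl)c1` is measured in an ADME assay on MDCK-II cells (Canis lupus familiaris) for permeability (on this read-out lower numbers stand for lower permeability and higher numbers for higher permeability), where compound 1 gives 19 10^-6 cm/s, the highest of the three numbers. Compound 2 `OC[C@@H](O[C@H]1CCCN(Cc2cccc3nonc23)[C@H]1c1ccccc1)c1cc(Cl)cc(Cl)c1` gives 11 10^-6 cm/s and compound 3 `O=C(O)c1ccc(CN2CCC[C@H](O[C@H](CO)c3cc(Cl)cc(Cl)c3)[C@@H]2c2ccccc2)cc1` gives 16 10^-6 cm/s, and the steps of a 1.7-fold lower number from compound 1 to compound 2 (0.24 log units; within the scatter) and a 1.2-fold lower number from compound 1 to compound 3 (0.07 log units; within the scatter) stay within the scatter. Compound 4 `Clc1cc(Cl)cc(CO[C@H]2CCCN(Cc3ncc[nH]3)[C@H]2c2ccccc2)c1` differs from compound 1 by hydrogen in place of hydroxymethyl on a saturated chain carbon bound to an aromatic carbon and an oxygen on a saturated carbon. For the measured compounds named here, every measured step swaps the group on the ring amine nitrogen; compounds 1, 2 and 3 all keep the hydroxymethyl group, so no measured step speaks to this change. The expectation for compound 4 is therefore a mildly higher number, with wide uncertainty, namely a 1.6-fold higher number from compound 1 to compound 4 (0.20 log units; within the scatter), giving an estimated 30 10^-6 cm/s with a range from 15 10^-6 cm/s to 60 10^-6 cm/s.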

Compound 4, apparent permeability: 2 10^-6 cm/s
Beside the measured number, compound 4's estimate is 15-fold (1.18 log units) above it; measured number below the stated range.
By their numbers in this assay, from the lowest: compound 4; then compounds 2, 3 and 1 (each within the scatter of the next).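

In this assay, for the compounds shown here, hydrogen in place of hydroxymethyl on this saturated chain carbon gives a 9.5-fold lower number from compound 1 to compound 4 (0.98 log units; beyond the scatter) and so lies beyond the scatter, while the earlier steps, all at the ring amine nitrogen, stayed within it. Among these compounds, then, this carbon is the first place where a change moves the number clearly. Nothing measured here explains the drop.

The compounds shown leave open whether the hydroxyl or the carbon of hydroxymethyl matters, which a methyl or an aminomethyl group at this carbon could help separate. They also leave open whether the drop recurs with the ring amine nitrogen groups of compound 2 and compound 3.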